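This account rests on a few compounds, and the source may have more. Where it says the series, first, only, none or still open, it means among the compounds named here.

Of the compounds shown here, two sharing one core have been measured so far. In a functional assay on CAKI-1 cells (Homo sapiens) for inhibition (a higher number here means a weaker inhibitor of growth, a lower number a stronger inhibitor of growth), compound 1 (`C=C1C(=O)O[C@H]2[C@H]1CC/C(COC(=O)N1CCC(F)(F)CC1)=C\CC[C@@]1(C)O[C@@H]21`) gives 2030 nM, while compound 2 (`C=C1C(=O)O[C@H]2[C@H]1CC/C(COC(=O)NCCN1CCCC1)=C\CC[C@@]1(C)O[C@@H]21`) gives 6860 nM, the higher of the two numbers and so the weaker inhibitor of growth in this pair. Compound 3 (`C=C1C(=O)O[C@H]2[C@H]1CC/C(COC(=O)Nc1n[nH]c(SC)n1)=C\CC[C@@]1(C)O[C@@H]21`) keeps the core and the amide-type nitrogen of compound 2, but carries 5-(methylsulfanyl)-1H-1,2,4-triazol-3-yl in place of 2-(pyrrolidin-1-yl)ethyl on an amide-type nitrogen. Within the data shown here, only one measured step bears on this change, and it bears only indirectly. That step, a 3.4-fold higher number from compound 1 to compound 2 (0.53 log units; beyond the scatter), was modest and exchanged the whole group on the same carbonyl carbon. Among the measured compounds shown here, no measured compound carries an aromatic ring on that nitrogen, so the direction rests on little more than compound 2 standing at the top of a narrow span, with 6860 nM as its value. A small move toward a lower number is therefore expected, possibly no larger than the scatter. The estimated change is a 1.7-fold lower number from compound 2 to compound 3 (0.23 log units; within the scatter). For compound 3 the expected value is 4000 nM, with an estimated range of 1500 nM to 11000 nM.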

Compound 3, concentration for 50% growth inhibition: 1990 nM
Compound 3: middle estimate off by 2.0-fold (0.30 log units), on the high side, and the stated range covers the measured number.
By their numbers in this assay, from the lowest: compounds 3 and 1 (each within the scatter of the next); then compound 2.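

In this assay, the amide-type nitrogen now has an aromatic ring on it, and 5-(methylsulfanyl)-1H-1,2,4-triazol-3-yl in place of 2-(pyrrolidin-1-yl)ethyl gives a 3.4-fold lower number from compound 2 to compound 3 (0.54 log units; beyond the scatter), a step opposite in direction to a 3.4-fold higher number from compound 1 to compound 2 (0.53 log units; beyond the scatter). The other comparison gives a 1.0-fold lower number from compound 1 to compound 3 (0.01 log units; within the scatter), so a compound with the amide hydrogen and one without it cannot be told apart here, while compound 2 and compound 3, which both keep that hydrogen, are separated beyond the scatter; the amide hydrogen alone therefore does not set the number in these three compounds. Nothing measured here accounts for either step.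

The compounds shown leave open whether the step from compound 2 belongs to the triazole ring, to the methylsulfanyl group on it, or to the departure of the pyrrolidine ring. A phenyl ring on the same nitrogen, the triazole with plain hydrogen in place of methylsulfanyl, or a simple butyl chain would each bear on that question.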